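This account rests on a few compounds, and the source may have more. Where it says the series, first, only, none or still open, it means among the compounds named here.

For the measured compounds named here, compound 2 `COc1cc(Cl)cc(-c2nn(-c3cccc(NC(=O)Nc4ccc(Cl)c(Cl)c4)c3)cc2-c2ccncc2)c1` is one of two compounds measured in a functional assay on NCI-H522 cells (Homo sapiens) for inhibition, read by sulforhodamine B assay, with a stated time of 48 h, tested at 0.01 uM (on this read-out higher numbers stand for a weaker effect at the one concentration tested and lower numbers for a stronger effect), where compound 2 gives 95%. Compound 1 `COc1cc(Cl)cc(-c2nn(-c3cccc(NC(=O)Nc4cc(C(F)(F)F)cc(C(F)(F)F)c4)c3)cc2-c2ccncc2)c1` gives 93% in this assay, a gap to compound 2 that lies within the scatter, so neither reads as stronger than the other. Compound 3 `COc1cc(Cl)cc(-c2nn(-c3cccc(NC(=O)Nc4cccc(C(F)(F)F)c4)c3)cc2-c2ccncc2)c1` has not yet been measured. The change from compound 2 to compound 3 is 3-(trifluoromethyl)phenyl in place of 3,4-dichlorophenyl on an amide-type nitrogen. Going by the values given here, with no step between measured compounds to lean on, the expected step of a number 1 percentage points lower from compound 2 to compound 3 (within the scatter) is estimated to stay within the scatter, in no direction beyond it. Compound 3 is expected to give 94%, estimated between 84% and 102%.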

Compound 3, a percentage reported as activity, at one concentration (the size of the read-out at that concentration, not a potency): 95%
Compound 3: middle estimate off by 1 percentage points, on the low side, within the range that was stated.
By their numbers in this assay, from the lowest: compounds 1, 2 and 3 (each within the scatter of the next).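

In this assay, the change at the amide-type nitrogen gives no change at the digits printed from compound 2 to compound 3 (within the scatter) and so shows that 3-(trifluoromethyl)phenyl and 3,4-dichlorophenyl cannot be told apart at this position. Removing one trifluoromethyl group gives a number 2 percentage points higher from compound 1 to compound 3 (within the scatter) and likewise leaves no readable difference. No evidence is available that would account for these results. Going by these compounds, whether a morpholine or a carboxylic acid on this phenyl ring would move the read-out remains open. So does whether these three compounds would separate at another concentration.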